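The source may report more compounds than this note shows. Statements on the series, on what has been measured and on what is new or still open speak of the compounds shown alone.

Compound 1 `Cc1cc(OCc2cccc(F)c2)ccc1CN[C@@H](C)C(N)=O` was tested in an assay on Sf9 cells for inhibition of Amine oxidase [flavin-containing] A (Homo sapiens), with stated times of 15 min and 60 min; a higher number here means a weaker inhibitor, a lower number a stronger inhibitor. In this assay compound 1 gives only a limit, > 10000 nM, so its true number is not known. Compound 2 `C#CCN(Cc1ccc(OCc2cccc(F)c2)cc1C)[C@@H](C)C(N)=O` gives 6400 nM in this assay, and the step of an at least 1.5-fold lower number from compound 1 to compound 2 (0.19 log units; that floor lies within the scatter) is floored because of the limit of > 10000 nM in this assay, at which 1 of the 2 values shown sits. Compound 3 `C[C@H](NCc1ccc(OCc2cccc(F)c2)cc1Cl)C(N)=O` carries chloro in place of methyl on an aromatic carbon. No measured step here covers this change; the only step shown alters the amine nitrogen instead, so it gives no direction. Compound 3 is therefore expected at about 12000 nM, between 3000 nM and 50000 nM, an estimated step that the limit leaves unreadable from compound 1 to compound 3.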

Compound 3, half-maximal inhibitory concentration: 12000 nM
Compound 3: the middle estimate sits on the measured number at the digits printed; the measured number falls inside the stated range.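

No step from compound 1 to compound 3 can be read, because compound 1 carries only a limit: the limit of > 10000 nM in this assay, at which 1 of the 3 values shown sits.

Going by these compounds, whether chloro or methyl at this place gives the stronger inhibitor remains open.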